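This account rests on a few compounds, and the source may have more. Where it says the series, first, only, none or still open, it means among the compounds named here.

Working notes on the series. Going by the values given here, the shared core of compound 1 `O=C(O)C(=O)CC(=O)c1ccc(-c2ccccc2)cc1` carries an unsubstituted outer ring, and in an assay on isolated protein (Sus scrofa) for inhibition of 2-Hydroxyacid oxidase 1 (Homo sapiens) (on this read-out higher numbers stand for weaker inhibition and lower numbers for stronger inhibition), compound 1 gives 1100 nM, the highest number of the three measured so far. Compound 2 `O=C(O)C(=O)CC(=O)c1ccc(-c2ccc(Br)cc2)cc1` carries a bromo group on that ring and gives 63 nM in this assay. Compound 3 `O=C(O)C(=O)CC(=O)c1ccc(-c2ccc(SCc3ccccc3)cc2)cc1` carries a benzylsulfanyl group there and gives 400 nM. The two substitutions both lower the number: a 17-fold lower number from compound 1 to compound 2 (1.24 log units; beyond the scatter), and a 2.8-fold lower number from compound 1 to compound 3 (0.44 log units; beyond the scatter); between the two substituted compounds, a 6.3-fold higher number from compound 2 to compound 3 (0.80 log units; beyond the scatter).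

Compound 4 `O=C(O)C(=O)CC(=O)c1ccc(-c2ccc(SCCc3ccncc3)cc2)cc1` is the next member: (2-(pyridin-4-yl)ethyl)sulfanyl in place of hydrogen on an aromatic carbon. The change is of the same kind as in compound 3, a sulfur-linked chain on the outer ring, here longer and ending in a pyridine ring rather than a benzene ring. The step from compound 1 to compound 3 is the one that bears most directly, a modest lowering; the step to compound 2 shows a larger lowering is possible with a small substituent, but compound 4 is closer in build to compound 3. A modest lowering is therefore expected, a 2.8-fold lower number from compound 1 to compound 4 (0.44 log units; beyond the scatter), without grounds for anticipating the larger effect seen for compound 2. For compound 4 the estimate in this assay is 400 nM, with a range of 150 nM to 1100 nM.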

Compound 4, half-maximal inhibitory concentration: 90 nM
For compound 4 the middle estimate is 4.4-fold (0.65 log units) above the measured one; the whole stated range lies above it.
By their numbers in this assay, from the lowest: compounds 2 and 4 (each within the scatter of the next); then compound 3; then compound 1.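

At the position para to a large group on the outer ring, a long sulfur-linked chain ending in a pyridine ring gives a large step (a 12-fold lower number from compound 1 to compound 4 (1.09 log units; beyond the scatter)), so a large lowering in this assay is not limited to the small bromo group, and the step between the two substituents lies within the scatter (a 1.4-fold higher number from compound 2 to compound 4 (0.15 log units; within the scatter)). Among the sulfur-linked groups, the end of the chain also counts: replacing phenyl with (pyridin-4-yl)methyl on the saturated chain carbon bound to sulfur gives a modest step (a 4.4-fold lower number from compound 3 to compound 4 (0.65 log units; beyond the scatter)), a change that both lengthens the chain and puts a nitrogen into the terminal ring. No measurement at hand accounts for these differences.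

The step from compound 3 to compound 4 cannot be divided between the longer chain and the ring nitrogen; a 2-phenylethylsulfanyl group or a (pyridin-4-yl)methylsulfanyl group at this position would separate the two. From the compounds shown here alone, the role of the sulfur link also stays open, and an oxygen link or a methylene link in its place would address it.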